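Removing One Methoxy Group From Compound 2

The compounds below may be only part of what the source reports. "The series", "measured", "known", "first", "only" and "open" are said of these compounds alone.

In an ADME assay on HBZY-1 cells (Rattus norvegicus) for cytotoxicity, read by MTT assay, with a stated time of 2 h (a higher number here means a weaker inhibitor, a lower number a stronger inhibitor), compound 1 (`O=C(/C=C/c1ccccc1C(F)(F)F)Nc1ccc(F)c(Cl)c1`) gives > 200000 nM, which is a limit of the assay and not a number. Compound 2 (`COc1cc(NC(=O)/C(C#N)=C/c2ccccc2C(F)(F)F)cc(OC)c1OC`) gives > 200000 nM, which is also a limit and not a number. Compound 2 therefore has no exact place on the scale, and the data so far amount to the limit of > 200000 nM in this assay, at which 2 of the 2 values shown sit. Compound 3 (`COc1ccc(NC(=O)/C(C#N)=C/c2ccccc2C(F)(F)F)cc1OC`) differs from compound 2 in one place, with hydrogen in place of methoxy on an aromatic carbon. Among the measured compounds shown here, no measured pair shows what this change does in this assay. Compound 2 offers only its limit of > 200000 nM, so no step beyond the usual scatter is expected. The estimated step is a number no higher from compound 2 to compound 3 (the limit leaves the size open). For compound 3 the estimated value is 200000 nM, with an expected range from 100000 nM to 400000 nM, and the assay may well report only a limit again.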

Compound 3, half-maximal inhibitory concentration: > 200000 nM
Compound 3 was reported as a limit; the forecaster's own chance of this, stated with the estimate: 75%; the middle value lies on the limit itself.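

Compound 2 and compound 3 both stop at a limit of the assay rather than a number, so no step can be read from swapping methoxy for hydrogen. Still open is where any of these compounds would fall on the scale of this assay, and whether this swap changes anything: the limit of > 200000 nM in this assay, at which 3 of the 3 values shown sit.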